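The source may hold more compounds than are shown below. What is called first, only, known or untested is meant among the compounds shown, and "the series" means these compounds.

Measured so far in an ADME assay on Vero cells (Chlorocebus sabaeus) for cytotoxicity, read by XTT assay, with a stated time of 72 h; on this read-out higher numbers stand for lower toxicity in this test and lower numbers for higher toxicity in this test:

Compound 1 `CC1=C(C(=O)Nc2ccc(Br)cc2)C(c2ccccc2)NC(=O)N1`: > 100000 nM
Compound 2 `CC1=C(C(=O)Nc2ccc(F)cc2)C(c2ccccc2)NC(=O)N1`: > 100000 nM
Compound 3 `COC(=O)C1=C(C)NC(=O)NC1c1ccc(F)cc1`: "non-toxic" (no number reported)

The value of compound 1 in this assay is a limit of the assay and not a number. The value of compound 2 is likewise a limit. For compound 3 no single number is given, only a verbal description of low toxicity.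

Compound 1 differs from compound 2 by bromo in place of fluoro on an aromatic carbon. The step that the two limits leave unreadable from compound 2 to compound 1 is not readable, since both of its ends sit at the limit of > 100000 nM in this assay, at which 2 of the 3 values shown sit. How the core of compound 3 differs from that of compound 2 is not broken down here.

Not yet measured is compound 4 `COC(=O)C1=C(C)NC(=O)NC1c1ccc(Br)cc1`, which differs from compound 3 by bromo in place of fluoro on an aromatic carbon, the same change as that from compound 2 to compound 1. Since that earlier change left both compounds at the limit, compound 4 is expected to stay at the limit as well, most likely reported as 100000 nM with a plausible range from 50000 nM to 300000 nM.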

Compound 4, half-maximal cytotoxic concentration: 100000 nM
The estimate for compound 4 equals the measured number at the digits printed; the measured number falls inside the stated range.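

Among the compounds shown here, compound 3 is described only as "non-toxic", with no number, while compound 4 gives 100000 nM in this assay, and no step between the two can be read. The compounds shown leave open whether bromo in place of fluoro on the aromatic ring changes this read-out at all.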